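This account rests on a few compounds, and the source may have more. Where it says the series, first, only, none or still open, it means among the compounds named here.

Compound 1 `CN(CC1CCCCC1)N1CCN(c2nc(=O)c3cc(C(F)(F)F)cc([N+](=O)[O-])c3s2)CC1` is tested in an ADME assay on Vero cells (Chlorocebus sabaeus) for cytotoxicity, read by MTT assay, with a stated time of 72 h (a lower number here means that less compound is tolerated, a higher number that more compound is tolerated), where compound 1 gives > 64 ug/mL, a limit of the assay rather than a number. Compound 2 `O=c1nc(N2CCN(NCc3ccc(C(F)(F)F)cc3)CC2)sc2c([N+](=O)[O-])cc(C(F)(F)F)cc12` gives > 64 ug/mL, again a limit. Compound 3 `COc1ccc(CNN2CCN(c3nc(=O)c4cc(C(F)(F)F)cc([N+](=O)[O-])c4s3)CC2)cc1` gives > 64 ug/mL, also a limit. The changes among these three, a step that the two limits leave unreadable from compound 1 to compound 2, a step that the two limits leave unreadable from compound 1 to compound 3 and a step that the two limits leave unreadable from compound 2 to compound 3, cannot be sized because of the limit of > 64 ug/mL in this assay, at which 3 of the 3 values shown sit. Compound 4 `CC(C)(C)c1ccc(CNN2CCN(c3nc(=O)c4cc(C(F)(F)F)cc([N+](=O)[O-])c4s3)CC2)cc1` differs from compound 1 by (4-(tert-butyl)benzyl)amino in place of (cyclohexylmethyl)(methyl)amino on an amine nitrogen in a ring. The measured changes on the same amine nitrogen in a ring give no readable size, so no step beyond the scatter is expected in this assay; the expected step is a number no higher from compound 1 to compound 4 (the limit leaves the size open). Compound 4 is estimated at 64 ug/mL, within 32 ug/mL to 100 ug/mL, most likely reported again as a limit.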

Compound 4, half-maximal cytotoxic concentration: > 64 ug/mL
Compound 4: no number, only a limit (the forecaster's own chance of this, stated with the estimate: 80%); the middle value sits exactly at the limit.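

The steps from compound 1, compound 2 and compound 3 to compound 4 cannot be read because all four compounds give the same reading: (the limit of > 64 ug/mL in this assay, at which 4 of the 4 values shown sit). Going by these compounds, what stays open is whether the compounds differ at all in this assay and at what concentration each one would reach the half-maximal cytotoxic effect.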